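Pyrazolylamino in place of methylpiperazinylamino: compound 4

A few compounds are considered here, and "the series" means these few. Any claim that something is new, unique, unknown or untested is made for them only; others in the source may bear on it.

Measured so far in a functional assay on HCC78 cells (Homo sapiens) for antiproliferative activity, read by MTT assay, with a stated time of 48 h; a higher number here means a weaker inhibitor, a lower number a stronger inhibitor:
compound 1 `COc1cccc(CNC(=O)c2cccc(C(C)Oc3cccnc3Nc3cnn(C)c3)c2)c1`, compound 1 gives 78600 nM
compound 2 `Cc1ccc(CNC(=O)c2cccc(C(C)Oc3ccnc(NN4CCN(C)CC4)c3)c2)cc1`, compound 2 gives 26200 nM
compound 3 `CC(Oc1ccnc(NN2CCN(C)CC2)c1)c1cccc(C(=O)NCc2ccc(Cl)c(C(F)(F)F)c2)c1`, compound 3 gives 23500 nM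

Among the measured compounds shown here, compound 3 and compound 2 give numbers within the scatter of each other, while compound 1 gives a number that lies beyond the scatter above both; compound 1 differs from the other two in more than one place, so no single step joins them. The one step that is shown, a 1.1-fold lower number from compound 2 to compound 3 (0.05 log units; within the scatter), touches only the benzylamide end of the molecule.

Compound 4 `CC(Oc1ccnc(Nc2cnn(CC(C)(C)O)c2)c1)c1cccc(C(=O)NCc2ccc(Cl)c(C(F)(F)F)c2)c1` is the next compound. It differs from compound 3 by 1-(2-hydroxy-2-methylpropyl)-1H-pyrazol-4-yl in place of 4-methylpiperazin-1-yl on a nitrogen on an aromatic ring. No measured step bears on this change: the only step shown lies elsewhere in the structure, and compound 1, which carries a pyrazolylamino group, sits on a different core and cannot be read as a paired comparison. Without a relevant step, the expectation for compound 4 in this assay rests on compound 3 alone, and a change within the scatter is the estimate, a 1.5-fold lower number from compound 3 to compound 4 (0.17 log units; within the scatter). Compound 4 is therefore expected to give about 16000 nM, with a range from 4000 nM to 60000 nM.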

Compound 4, half-maximal inhibitory concentration: > 100000 nM
Compound 4 was reported as a limit (the forecaster's own chance of this, stated with the estimate: 10%); middle value at least 6.2-fold (0.79 log units) away from the limit.
By their numbers in this assay, from the lowest: compounds 3 and 2 (each within the scatter of the next); then compound 1. At a limit, above all of these: compound 4.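

In this assay, replacing 4-methylpiperazin-1-yl with 1-(2-hydroxy-2-methylpropyl)-1H-pyrazol-4-yl on the nitrogen on an aromatic ring gives an at least 4.2-fold higher number from compound 3 to compound 4 (0.62 log units; beyond the scatter). This is the only single change shown that lies beyond the scatter, whereas the one earlier step, at the benzylamide end, stayed within it, so this position responds to a change where that end did not. The value of compound 4 is a limit, and the step gives only a minimum size: the limit of > 100000 nM in this assay, at which 1 of the 4 values shown sits.

The compounds shown leave open whether the weaker result belongs to the pyrazole ring or to its 2-hydroxy-2-methylpropyl chain, a question that a 1H-pyrazol-4-yl group carrying no chain, on the same nitrogen and the same core, would address. They also leave open how a piperidin-4-yl group at this position would read.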